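Replacing a 4-Methoxybenzyl Ether with a 3-Methylbenzyl Ether

A few compounds are considered here, and "the series" means these few. Any claim that something is new, unique, unknown or untested is made for them only; others in the source may bear on it.

Measured compounds:
compound 1 `COc1ccc(COc2ccc3c(Cn4ccnc4)cc(=O)oc3c2)cc1OC` — 0%
compound 2 `COc1ccc(COc2ccc3c(Cn4ccnc4)cc(=O)oc3c2)cc1` — 1%

In an assay for inhibition of steroid 17-alpha-hydroxylase/17,20 lyase (Homo sapiens), read by HPLC, with a stated time of 5 min, tested at 2.5 uM, in the presence of a further agent that is not named here (a higher number here means more inhibition at the concentration tested (going by the name of the read-out), a lower number less inhibition), compound 1 gives 0%, and compound 2 gives 1%. Within the data shown here, compound 2 carries the higher of the two numbers, but the single known step, a number 1 percentage points higher from compound 1 to compound 2 (within the scatter), lies within the scatter, so the two compounds cannot be told apart on these data. Compound 3 `Cc1cccc(COc2ccc3c(Cn4ccnc4)cc(=O)oc3c2)c1` has not yet been measured. It differs from compound 2 by 3-methylphenyl in place of 4-methoxyphenyl on a saturated chain carbon bound to an oxygen on an aromatic ring. Among the measured compounds shown here, the one measured step concerns hydrogen in place of methoxy on an aromatic carbon and was small; no measured step touches the 3-methylphenyl or the 3-methylbenzyl. Because compound 2 gives 1% and compound 1 gives 0%, the expected step is a number 1 percentage points higher from compound 2 to compound 3 (within the scatter), none beyond the scatter. Compound 3 is estimated at 2%, between 0% and 12%.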

Compound 3, a percentage reported as inhibition, at one concentration (the size of the read-out at that concentration, not a potency): 0%
For compound 3 the middle estimate is 2 percentage points above the measured one; low and high end bracket the measured number.
By their numbers in this assay, from the lowest: compounds 1, 3 and 2 (each within the scatter of the next).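

Exchanging 4-methoxyphenyl for 3-methylphenyl on a saturated chain carbon bound to an oxygen on an aromatic ring gives a number 1 percentage points lower from compound 2 to compound 3 (within the scatter) in this assay, so this change cannot be told from no change on these data. The earlier step touched only a methoxy group, whereas this one replaces the whole 4-methoxybenzyl with 3-methylbenzyl, and compound 3 still gives 0%, so a second kind of change at this position leaves the read-out near nil. No available evidence bears on this result.

As far as these compounds go, it remains open whether any group at this position would give clear inhibition at the tested concentration. An amine or a carboxylic acid on the benzyl ring, or a longer chain between that ring and the ether oxygen, could answer this.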